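Shortening the Chloropropyl Chain on a Weakly Active Sulfonamide Urea

A few compounds are considered here, and "the series" means these few. Any claim that something is new, unique, unknown or untested is made for them only; others in the source may bear on it.

Measured compounds:
compound 1: `O=C(NCCCCl)Nc1ccc(S(=O)(=O)Oc2ccc(O)cc2)cc1`, 51000 nM
compound 2: `Cc1ccccc1NS(=O)(=O)c1ccc(NC(=O)NCCCCl)cc1`, > 200000 nM

Both compounds were tested in a functional assay on MCF7 cells (Homo sapiens) for cytotoxicity, read by sulforhodamine B assay, with a stated time of 48 h; on this read-out lower numbers stand for stronger inhibition and higher numbers for weaker inhibition. Compound 1 gives 51000 nM. For compound 2 the assay reports only a limit, > 200000 nM, so its true number is not known. Within the data shown here, the single measured step, an at least 3.9-fold higher number from compound 1 to compound 2 (0.59 log units; beyond the scatter), concerns the group on the sulfonyl sulfur; its size is open-ended because compound 2 sits at the limit of > 200000 nM in this assay, at which 1 of the 2 values shown sits.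

Compound 3 is `CCNC(=O)Nc1ccc(S(=O)(=O)Nc2ccccc2C)cc1`. It differs from compound 2 in one place: hydrogen in place of chloromethyl on a saturated chain carbon, two bonds along the chain from an amide-type nitrogen. Among the measured compounds shown here, no measured step touches this chain, so the only measured step gives no direct guidance on the direction of the change. Compound 2 is already at a limit, and the change removes the chloromethyl end of the chain without adding any new group, so compound 3 is expected to show no step beyond the scatter. Compound 3 is therefore expected to give about 250000 nM, within a range from 100000 nM to 700000 nM, which is the expected step that the limit leaves unreadable from compound 2 to compound 3.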

Compound 3, half-maximal inhibitory concentration: > 200000 nM
Compound 3 gave a limit, no number; the forecaster's own chance of this, stated with the estimate: 75%; the middle value lies beyond the limit too.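

Compound 2 and compound 3 each give only a limit, not a number, so no step between them can be read: the limit of > 200000 nM in this assay, at which 2 of the 3 values shown sit.

The compounds shown leave open whether ethyl in place of 3-chloropropyl changes the result at all, and how far each compound's true number lies past that limit.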